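The source may hold more compounds than are shown below. What is called first, only, known or untested is meant among the compounds shown, and "the series" means these compounds.

Measured in a functional assay on MCF-A cells (Homo sapiens) for cytotoxicity; on this read-out lower numbers stand for stronger inhibition of growth and higher numbers for weaker inhibition of growth:
- compound 1 `COc1ccc(C2=C(c3cc(OC)c(OC)c(OC)c3)CC3CCCN3C2=O)cc1O`: > 100000 nM, a limit of the assay and not a number
- compound 2 `CSc1ccc(C2=C(c3ccc(F)c(F)c3)C(=O)N3CCCC3C2)cc1`: 800 nM
- compound 3 `CSc1ccc(C2=C(c3ccc(C)c(C)c3)C(=O)N3CCCC3C2)cc1`: 800 nM

Compound 3 stands level with compound 2, the nearest measured neighbour. Compound 4 `CSc1ccc(C2=C(c3ccc(O)cc3)C(=O)N3CCCC3C2)cc1` differs from compound 3 by 4-hydroxyphenyl in place of 3,4-dimethylphenyl on a double-bonded ring carbon. Among the compounds with values here, the one measured step at this place, no change at the digits printed from compound 2 to compound 3 (within the scatter), exchanged 3,4-difluorophenyl for 3,4-dimethylphenyl and tells nothing directly about a hydroxy group. With so little to go on, only a modest step is expected, a 1.9-fold higher number from compound 3 to compound 4 (0.27 log units; within the scatter), toward weaker inhibition of growth. For compound 4 the estimated value is 1500 nM, with an expected range from 400 nM to 8000 nM.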

Compound 4, concentration for 50% growth inhibition: > 100000 nM
Compound 4 was reported as a limit; the forecaster's own chance of this, stated with the estimate: 5%; middle value at least 66-fold (1.82 log units) from the limit.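

In this assay, the place on the double-bonded ring carbon proved sensitive to the group it carries: the 3,4-difluorophenyl and 3,4-dimethylphenyl groups gave no change at the digits printed from compound 2 to compound 3 (within the scatter), whereas 4-hydroxyphenyl gave an at least 120-fold higher number from compound 3 to compound 4 (2.09 log units; beyond the scatter) and an at least 120-fold higher number from compound 2 to compound 4 (2.09 log units; beyond the scatter). Compound 4 carries a limit of the assay and not a number, so the true size of both steps stays unknown: the limit of > 100000 nM in this assay, at which 2 of the 4 values shown sit.

The compounds shown leave open whether the hydroxy group itself accounts for the loss. A plain phenyl, a methoxy group or an amine in its place could separate these possibilities.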